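The source may report more compounds than this note shows. Statements on the series, on what has been measured and on what is new or still open speak of the compounds shown alone.

Measured so far:
compound 1, `CC1CCN(c2cccc(Nc3nccc(-c4cccs4)n3)c2)CC1`, with 3500 nM in a functional assay for inhibition, with Homo sapiens as the target; a higher number here means a weaker inhibitor, a lower number a stronger inhibitor;
compound 2, `CC1CCN(c2cccc(Nc3nccc(-c4cccnc4)n3)c2)CC1`, with 1200 nM;
compound 3, `Cc1cccc(Nc2nccc(-c3ccco3)n2)c1`, with 2100 nM.

Compound 3 sits between the other two in this assay, but its gaps to compound 1 and to compound 2 both lie within the usual scatter, so it cannot be called stronger or weaker than either. Within the data shown here, the only step measured so far, a 2.9-fold lower number from compound 1 to compound 2 (0.46 log units; beyond the scatter), concerns a swap of the five- or six-membered ring on the shared core, a different place from the one changed here.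

Compound 4, `CC1CCN(c2cccc(Nc3nccc(-c4ccco4)n3)c2)CC1`, differs from compound 3 by 4-methylpiperidin-1-yl in place of methyl on an aromatic carbon. Among the measured compounds shown here, no measured pair isolates this change, so there is no direct guide. Since compound 1 and compound 2 both carry this larger group and give numbers close to that of compound 3, the change is expected to move the number little, with a 1.1-fold higher number from compound 3 to compound 4 (0.06 log units; within the scatter) as the estimated step. Compound 4 is therefore estimated at 2400 nM, with a range from 900 nM to 6500 nM.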

Compound 4, half-maximal inhibitory concentration: 5000 nM
The estimate for compound 4 lay 2.1-fold (0.32 log units) below the measured number, within the range that was stated.
By their numbers in this assay, from the lowest: compounds 2, 3, 1 and 4 (each within the scatter of the next, the first and the last beyond it).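

Replacing methyl with 4-methylpiperidin-1-yl on an aromatic carbon in this assay gives a 2.4-fold higher number from compound 3 to compound 4 (0.38 log units; beyond the scatter) and so offers a direct reading of this position, where the larger group gives a weaker inhibitor. With that group held in place, furan-2-yl in place of pyridin-3-yl gives a 4.2-fold higher number from compound 2 to compound 4 (0.62 log units; beyond the scatter) and furan-2-yl in place of thiophen-2-yl gives a 1.4-fold higher number from compound 1 to compound 4 (0.15 log units; within the scatter) so the furan-2-yl and thiophen-2-yl compounds cannot be told apart, while compound 2 remains the strongest of these three. No measurement available here explains either change.

Among these compounds, only one pair of compounds shows the methyl swap, so its size with pyridin-3-yl or thiophen-2-yl on the shared core stays open. From the compounds shown here alone, how an amine or a carboxylic acid at this position would compare also remains unknown.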